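This account rests on a few compounds, and the source may have more. Where it says the series, first, only, none or still open, it means among the compounds named here.

Among the measured compounds shown here, compound 2 `CC(=O)N[C@H]1[C@H]([C@@H](O)[C@H](O)CNC(=O)c2ccc(Cl)cc2)O[C@@](OCc2ccccc2)(C(=O)O)C[C@@H]1O` is one of two compounds measured in an in vitro assay on cells for binding affinity to myelin-associated glycoprotein (Mus musculus), read by surface plasmon resonance; on this read-out lower numbers stand for tighter binding and higher numbers for weaker binding. In this assay compound 2 gives 17000 nM, the lower of the two numbers. The other is compound 1 `CO[C@]1(C(=O)O)C[C@H](O)[C@@H](NC(C)=O)[C@H]([C@@H](O)[C@H](O)CNC(=O)c2ccccc2)O1`; in this assay compound 1 gives 137000 nM, a number that sits well beyond the scatter from that of compound 2. The two compounds differ in more than one place, so their pair yields no single step, and no cause for the gap can be drawn from it.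

Compound 3 `CC(=O)N[C@H]1[C@H]([C@@H](O)[C@H](O)CNC(=O)c2ccc(Cl)cc2)O[C@@](OCc2ccc(Cl)cc2)(C(=O)O)C[C@@H]1O` has not yet been measured. It differs from compound 2 in one place: chloro in place of hydrogen on an aromatic carbon. This change lands on an aromatic carbon of a six-membered aromatic ring of carbon only, on the benzyl part of the benzyloxy group, so that phenyl becomes 4-chlorophenyl.

For the measured compounds named here, no measured pair in this set isolates this kind of change, so the expectation rests on the shape of the series alone. For compound 3 the expected step is estimated as a 1.9-fold lower number from compound 2 to compound 3 (0.28 log units; within the scatter). The estimate for compound 3 in this assay is 9000 nM, with a range from 3000 nM to 30000 nM.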

Compound 3, dissociation constant: 15000 nM
Beside the measured number, compound 3's estimate is 1.7-fold (0.22 log units) below it, and the stated range covers the measured number.
By their numbers in this assay, from the lowest: compounds 3 and 2 (each within the scatter of the next); then compound 1.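

Among the compounds shown here, compound 2 and compound 3 form the first pair in this set that differs in one place, so the effect of a single change can be read for the first time. In this assay, chloro in place of hydrogen on an aromatic carbon, para to a large group, turning benzyl into 4-chlorobenzyl, gives a 1.1-fold lower number from compound 2 to compound 3 (0.05 log units; within the scatter), which lies within the scatter, so at this position the chloro leaves the reading indistinguishable from that of the unsubstituted benzyl group. Nothing available explains why this change leaves the number within the scatter, as no independent measurement bears on it.

From the compounds shown here alone, whether a different group on this same aromatic carbon, such as a methoxy, a nitrile or an amine, would also stay within the scatter remains open, as does the outcome of replacing the benzyl part with a longer chain. Compound 1 still differs from compound 2 in more than one place, so which of those differences accounts for the gap between them also remains unresolved.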